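Swapping bromo for fluoro on the shared core

The source may hold more compounds than are shown below. What is called first, only, known or untested is meant among the compounds shown, and "the series" means these compounds.

Measured so far: compound 1 `CC1(C)N=C(N)N=C(N)N1c1cccc(C(O)c2ccccc2)c1` gives 4.17 in a functional assay on L5178Y cells (Mus musculus); a higher number here means a more potent compound, by a factor of ten per unit of this negative logarithm, a lower number a less potent compound; compound 2 `CC1(C)N=C(N)N=C(N)N1c1cccc(Br)c1` gives 5.9.

Compound 2 stands highest of the two numbers, its nearest neighbour being compound 1 by the step of a number 1.73 log units higher from compound 1 to compound 2 (beyond the scatter). Compound 3 `CC1(C)N=C(N)N=C(N)N1c1cccc(F)c1` differs from compound 2 by fluoro in place of bromo on an aromatic carbon. Among the compounds with values here, no measured step concerns a swap of one halogen for another, so the one step recorded offers only an indirect guide. A modest loss is expected, giving the step of a number 0.50 log units lower from compound 2 to compound 3 (beyond the scatter). Compound 3 is estimated at 5.4, within a range of 4.7 to 6.1.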

Compound 3, logarithm of the reciprocal of the active concentration, log(1/C): 5.24
Beside the measured number, compound 3's estimate is 0.16 log units above it; low and high end bracket the measured number.
By their numbers in this assay, from the lowest: compound 1; then compound 3; then compound 2.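

On this aromatic carbon, the choice of halogen matters in this assay: fluoro does not match bromo (a number 0.66 log units lower from compound 2 to compound 3 (beyond the scatter)). Fluoro nonetheless remains ahead of hydroxy(phenyl)methyl (a number 1.07 log units higher from compound 1 to compound 3 (beyond the scatter)), so both halogens in this small set outperform that larger group. Nothing available accounts for either step. Still open, going by these compounds, is where chloro would fall relative to fluoro and bromo. Also open, on these data alone, is whether an amine, a methoxy group or a longer alkyl chain on this carbon would stand nearer the halogens or hydroxy(phenyl)methyl.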